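Swapping an Ethyl Chain for Cyclopropylmethyl

A few compounds are considered here, and "the series" means these few. Any claim that something is new, unique, unknown or untested is made for them only; others in the source may bear on it.

Of the compounds shown here, three have been measured in an assay on CHO cells for displacement of a labelled ligand from melanin-concentrating hormone receptor 1 (Homo sapiens), read by scintillation counting, with a stated time of 1 h; on this read-out higher numbers stand for weaker inhibition and lower numbers for stronger inhibition. Compound 1 `Cc1c(C2CC2)nc2cnc(-n3ccc(OCc4ccc(Cl)cc4)cc3=O)cn12` gives 44 nM. Compound 2 `Cc1c(C2CC2)nc2ncc(-n3ccc(OCc4ccc(Cl)cc4)cc3=O)cn12` reaches only the limit of this assay, > 1000 nM, which marks a limit rather than a number. Compound 3 `CCc1nc2ccc(-n3ccc(OCc4ccc(F)cc4)cc3=O)cc2n1C` gives 48 nM in this assay. Of the two compounds that return a number, compound 3 and compound 1 sit within the usual scatter of each other, so neither can be called the stronger binder; compound 3 simply stands alongside compound 1, and apart from compound 2, which gave only a limit.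

Compound 4 `Cn1c(CC2CC2)nc2ccc(-n3ccc(OCc4ccc(F)cc4)cc3=O)cc21` differs from compound 3 in one place: cyclopropyl in place of methyl on a saturated chain carbon bound to an aromatic carbon. Read one bond further out, the ethyl chain of compound 3 becomes a cyclopropylmethyl chain in compound 4, while the rest of the molecule is unchanged. Within the data shown here, no measured pair shows this change, so the expectation is that such a small extension of a saturated chain leaves the binding within the scatter, with no step beyond it in either direction. The expected step is a 1.1-fold lower number from compound 3 to compound 4 (0.03 log units; within the scatter). Compound 4 is therefore estimated at 45 nM in this assay, with a likely range from 15 nM to 140 nM.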

Compound 4, half-maximal inhibitory concentration: 90 nM
Compound 4: middle estimate off by 2.0-fold (0.30 log units), on the low side; the measured number falls inside the stated range.
By their numbers in this assay, from the lowest: compounds 1, 3 and 4 (each within the scatter of the next, the first and the last beyond it). At a limit, above all of these: compound 2.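

Among these compounds, compound 3 and compound 4 form the only pair so far that differs in one place, and cyclopropyl in place of methyl on a saturated chain carbon bound to an aromatic carbon gives a 1.9-fold higher number from compound 3 to compound 4 (0.27 log units; within the scatter). The ethyl chain can therefore become a cyclopropylmethyl chain, adding a three-membered ring of carbon, with no difference that this assay can separate from the scatter between repeated measurements, so this place in the molecule accepts the larger group in this one pair. Among the compounds shown here, none of the information at hand explains this outcome, and the single reading supports no statement about a cause, so it stands as an observation.

What the compounds shown leave open is how far this acceptance extends, since one pair on one core says nothing about a longer chain such as n-butyl, a carboxylic acid or an amine at the same place. From the compounds shown here alone, it also remains open whether the same exchange of methyl for cyclopropyl would give a similar result on the core of compound 1, where the surrounding structure is different.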